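Swapping 4-isopropylphenyl for 3-fluorophenyl on the amide nitrogen

This account rests on a few compounds, and the source may have more. Where it says the series, first, only, none or still open, it means among the compounds named here.

Within the data shown here, in a functional assay on MCF7 cells (Homo sapiens) for inhibition, read by MTT assay, with a stated time of 72 h (on this read-out lower numbers stand for stronger inhibition and higher numbers for weaker inhibition), compound 1 (`CC(C)c1ccc(NC(=O)C2CCN(C/C=C/c3ccccc3)CC2)cc1`) gives 9100 nM and stands within the scatter of compound 2 (`CCCCc1ccc(NC(=O)C2CCN(C/C=C/c3ccccc3)CC2)cc1`) at 5870 nM in the only pair measured so far. Compound 3 (`O=C(Nc1cccc(F)c1)C1CCN(C/C=C/c2ccccc2)CC1`) carries this change: 3-fluorophenyl in place of 4-isopropylphenyl on an amide-type nitrogen and no other. Among the measured compounds shown here, the one measured step (a 1.6-fold lower number from compound 1 to compound 2 (0.19 log units; within the scatter)) replaces isopropyl with butyl and does not test a 3-fluorophenyl group, so it offers weak guidance and no direction. The expected change (a 1.1-fold higher number from compound 1 to compound 3 (0.04 log units; within the scatter)) therefore stays within the scatter. For compound 3 the estimated value is 10000 nM (expected range 4000 nM to 25000 nM).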

Compound 3, half-maximal inhibitory concentration: 33000 nM
Estimate against measurement, compound 3: 3.3-fold (0.52 log units) below; the whole stated range lies below it.
By their numbers in this assay, from the lowest: compounds 2 and 1 (each within the scatter of the next); then compound 3.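

In this assay the group on the amide-type nitrogen proves able to shift the number beyond the scatter (a 3.6-fold higher number from compound 1 to compound 3 (0.56 log units; beyond the scatter)), which the swap of isopropyl for butyl did not do. Here 3-fluorophenyl goes with weaker inhibition than 4-isopropylphenyl, but the step changes both the substituent and its ring position at once, so the two cannot be separated. No evidence available here bears on the reason for this shift. The compounds shown leave open how 4-fluorophenyl or unsubstituted phenyl would read on this nitrogen, and whether a ring bearing an amine or a longer chain would follow the same trend.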